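The compounds below may be only part of what the source reports. "The series", "measured", "known", "first", "only" and "open" are said of these compounds alone.

Notes on the series. In a functional assay on HEK293 cells for agonist activity at D(4) dopamine receptor (Homo sapiens), read by FLIPR (a lower number here means that less compound is needed, a higher number that more compound is needed for the effect), compound 1 `O=C(NCN1CCC(c2cccc[n+]2[O-])CC1)c1ccccc1` gives 532 nM, compound 2 `O=C(NCN1CCC(c2cccc[n+]2[O-])CC1)c1cnccc1Cl` gives 1290 nM and compound 3 `O=C(NCN1CCC(c2cccc[n+]2[O-])CC1)c1ccc(F)c(Cl)c1` gives 63 nM. Compound 3 holds the lowest number of the three: an 8.4-fold lower number from compound 1 to compound 3 (0.93 log units; beyond the scatter) and a 20-fold lower number from compound 2 to compound 3 (1.31 log units; beyond the scatter), while a 2.4-fold higher number from compound 1 to compound 2 (0.38 log units; beyond the scatter). Compound 4 `O=C(NCN1CCC(c2cccc[n+]2[O-])CC1)c1ccc(OC(F)(F)F)c(Cl)c1` differs from compound 3 only by trifluoromethoxy in place of fluoro on an aromatic carbon. Among the measured compounds shown here, no measured step alters a single substituent on that ring; the two steps that lower the number each exchange the whole aryl group, so they give no direct guide to this change. The step is therefore expected to stay small, a 1.3-fold higher number from compound 3 to compound 4 (0.10 log units; within the scatter), with the direction uncertain. Compound 4 is estimated at 80 nM in this assay, expected within 25 nM to 250 nM.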

Compound 4, half-maximal effective concentration: 170 nM
Estimate against measurement, compound 4: 2.1-fold (0.33 log units) below; the range from low to high includes it.
By their numbers in this assay, from the lowest: compound 3; then compound 4; then compound 1; then compound 2.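

Among the compounds shown here, with the chloro group kept, this is the first single-substituent change on this ring: trifluoromethoxy in place of fluoro gives a 2.7-fold higher number from compound 3 to compound 4 (0.43 log units; beyond the scatter) in this assay. The position para to a large group therefore affects the number, and here the group of 5 heavy atoms costs modestly compared with the single fluoro atom. No available evidence accounts for this step.

From the compounds shown here alone, it remains open how a methoxy group or an amine would read at this position, and whether the step would persist without the chloro group.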